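A few compounds are considered here, and "the series" means these few. Any claim that something is new, unique, unknown or untested is made for them only; others in the source may bear on it.

Measured in a functional assay on SW480 cells (Homo sapiens) for antiproliferative activity, read by MTT assay, with a stated time of 48 h; on this read-out lower numbers stand for stronger inhibition and higher numbers for weaker inhibition:
- compound 1 `CCCCC(CCO)n1cnc2c(Cl)ncnc21`: > 50000 nM (a limit)
- compound 2 `CCCCC(CCO)n1cnc2c(OC)ncnc21`: > 50000 nM (a limit)
- compound 3 `CCCCC(CCO)n1cnc2cncnc21`: > 50000 nM (a limit)

Compound 2 has no exact number, only the limit > 50000 nM. The whole set stands at the limit of > 50000 nM in this assay, at which 3 of the 3 values shown sit.

Compound 4 `CCCCCCCCCC(CCO)n1cnc2c(OC)ncnc21` is the next to be tested, and its structure departs from that of compound 2 as follows: pentyl in place of hydrogen on a saturated chain carbon, five bonds along the chain from an aromatic nitrogen. Put simply, the chain grows longer, with pentyl in place of hydrogen.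

The measured steps are a step that the two limits leave unreadable from compound 1 to compound 2, a step that the two limits leave unreadable from compound 1 to compound 3 and a step that the two limits leave unreadable from compound 2 to compound 3. Each swaps a group on an aromatic carbon and leaves the chain untouched, and none has a size that can be carried over. The expectation therefore rests on the structural change alone, and it is a cautious one: some weak activity may appear in this assay, though another limit is quite possible.

The estimate means an at least 1.7-fold lower number from compound 2 to compound 4 (0.25 log units; that floor lies within the scatter), an expected move towards lower numbers.

For compound 4 the estimated value is 28000 nM, with an expected range from 9000 nM to 70000 nM.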

Compound 4, half-maximal inhibitory concentration: 3250 nM
Compound 4: the middle estimate sits 8.6-fold (0.94 log units) above what was measured, and the stated range ends above it.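

In this assay, the chain proves to be a place where a change can be read: pentyl in place of hydrogen on a saturated chain carbon, five bonds along the chain from an aromatic nitrogen, gives an at least 15-fold lower number from compound 2 to compound 4 (1.18 log units; beyond the scatter). The earlier swaps on an aromatic carbon showed nothing comparable, as the steps among compound 1, compound 2 and compound 3 cannot be read. Compound 4 is the only compound here with an exact number, and the others remain at a limit: the limit of > 50000 nM in this assay, at which 3 of the 4 values shown sit.

Only this one chain length is shown with a readable value, so it remains open whether a shorter or a longer chain would give a larger or smaller step. It is also unknown whether chloro or hydrogen in place of methoxy would matter on this longer chain, or how an amine on the chain would compare.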